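Swapping the aryl group on the tetrazole for a benzyl group

The source may hold more compounds than are shown below. What is called first, only, known or untested is meant among the compounds shown, and "the series" means these compounds.

Measured compounds in an ADME assay on S9 fraction from liver (Rattus norvegicus) for metabolic stability, read by LC-MS, using NADPH, with a stated time of 30 min; on this read-out higher numbers stand for a more stable compound and lower numbers for a less stable compound:
compound 1 `CCCCCCCCc1ccc(OCC(=O)Cn2nnc(-c3cccc(Cl)c3)n2)cc1` gives 69%;
compound 2 `CCCCCCCCc1ccc(OCC(=O)Cn2nnc(-c3ccc(C(=O)OC)cc3)n2)cc1` gives 64%;
compound 3 `CCCCCCCCc1ccc(OCC(=O)Cn2nnnc2-c2ccc(Cl)cc2)cc1` gives 45%.

Compound 3 has the lowest of the three numbers; compound 2 is the nearest and compound 1 the furthest, both beyond the scatter. Compound 4 `CCCCCCCCc1ccc(OCC(=O)Cn2nnnc2Cc2ccccc2)cc1` has not been measured. It differs from compound 3 by benzyl in place of 4-chlorophenyl on an aromatic carbon. Among the compounds with values here, the only measured step is an aryl-for-aryl swap at a different position, which gave a number 5 percentage points lower from compound 1 to compound 2 (within the scatter); no step shows an aryl replaced by a benzyl, so there is no direct precedent for this change. On that thin basis no shift beyond the scatter is expected in this assay, with no change at the digits printed from compound 3 to compound 4 (within the scatter). Compound 4 is therefore estimated at 45%, within 25% to 65%.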

Compound 4, percent of the compound remaining: 26%
Beside the measured number, compound 4's estimate is 19 percentage points above it; the range from low to high includes it.
By their numbers in this assay, from the lowest: compound 4; then compound 3; then compounds 2 and 1 (each within the scatter of the next).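

In this assay, benzyl in place of 4-chlorophenyl gives a number 19 percentage points lower from compound 3 to compound 4 (beyond the scatter). This position therefore responds to a change of group, even though both groups have the same count of heavy atoms and one carbon-only aromatic ring. The other step shown, a number 5 percentage points lower from compound 1 to compound 2 (within the scatter), was an aryl swap at a different place, so it could not show this. Nothing measured here explains the drop. As far as these compounds go, what remains open is whether the result follows the lost chlorine or the added methylene link, which change together here; a 4-chlorobenzyl group on this carbon would separate the two.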